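The source may hold more compounds than are shown below. What is called first, only, known or untested is meant among the compounds shown, and "the series" means these compounds.

Measured so far:
compound 1 `CCCCCCCCCCn1cc(-c2nc3ccccc3cc2CCC)nn1` — > 100 ug/mL
compound 2 `CCc1cc2ccccc2nc1-c1cn(CCC(F)(F)C(F)(F)C(F)(F)C(F)(F)C(F)(F)C(F)(F)C(F)(F)C(F)(F)F)nn1` — 95.2 ug/mL
compound 3 `CCCCCCCCCCn1cc(-c2nc3ccccc3cc2C)nn1` — 44.5 ug/mL

In a functional assay on COLO 205 cells (Homo sapiens) for cytotoxicity, read by MTT assay, with a stated time of 24 h (on this read-out lower numbers stand for stronger inhibition and higher numbers for weaker inhibition), compound 1 gives only a limit, > 100 ug/mL; it is one of the values sitting at the limit of > 100 ug/mL in this assay, at which 1 of the 3 values shown sits. Of the two measured numbers, compound 2 holds the higher one, and the nearest number, that of compound 3, lies below it by a gap beyond the scatter.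

Compound 4 `Cc1cc2ccccc2nc1-c1cn(CCC(F)(F)C(F)(F)C(F)(F)C(F)(F)C(F)(F)C(F)(F)C(F)(F)C(F)(F)F)nn1` has not yet been run in this assay. It differs from compound 2 by hydrogen in place of methyl on a saturated chain carbon bound to an aromatic carbon.

Going by the values given here, one measured step bears on this change: an at least 2.2-fold lower number from compound 1 to compound 3 (0.35 log units; beyond the scatter). There the same place on the shared core was shortened in the same way, and the number fell by a modest amount. Compound 2 already carries the shorter ethyl chain on the same core, so the same direction is expected here, at a similar, modest size.

Compound 4 is therefore estimated at 45 ug/mL in this assay, with a range from 22 ug/mL to 90 ug/mL, meaning an expected step of a 2.1-fold lower number from compound 2 to compound 4 (0.33 log units; beyond the scatter).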

Compound 4, half-maximal inhibitory concentration: 75.8 ug/mL
For compound 4 the middle estimate is 1.7-fold (0.23 log units) below the measured one, and the stated range covers the measured number.
By their numbers in this assay, from the lowest: compounds 3, 4 and 2 (each within the scatter of the next, the first and the last beyond it). At a limit, above all of these: compound 1.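

In this assay, the ethyl to methyl change at this place gives a 1.3-fold lower number from compound 2 to compound 4 (0.10 log units; within the scatter), so this smaller cut on the saturated chain carbon bound to an aromatic carbon does not resolve from the scatter. The earlier, larger cut at the same place, an at least 2.2-fold lower number from compound 1 to compound 3 (0.35 log units; beyond the scatter), was beyond the scatter, so shortening here does not move the number past the scatter in every case, and the two pairs carry different chains elsewhere on the shared core. Compound 1 gives only a limit, which leaves the size of that earlier step open-ended: the limit of > 100 ug/mL in this assay, at which 1 of the 4 values shown sits.

The two pairs do not separate the size of the cut from the influence of the other chain. Also open, on these data alone, is how an amine, a carboxylic acid or a butyl chain at this place would read.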